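Nitro in Place of Bromo: What to Expect for Compound 4

The source may report more compounds than this note shows. Statements on the series, on what has been measured and on what is new or still open speak of the compounds shown alone.

Measured compounds in an assay (Equus caballus) for inhibition of Thromboxane-A synthase (Homo sapiens), using microsomes; on this read-out higher numbers stand for weaker inhibition and lower numbers for stronger inhibition:
compound 1, `O=C(O)CCCC/C=C(\c1cccnc1)c1cccc(Br)c1`, 180 nM
compound 2, `Cc1ccsc1/C(=C/CCCCC(=O)O)c1cccnc1`, 29 nM
compound 3, `O=C(O)CCCC/C=C(/c1ccc(Br)cc1)c1cccnc1`, 82 nM

Compound 1 stands highest of the three numbers: the nearest is compound 3, reached by a 2.2-fold lower number from compound 1 to compound 3 (0.34 log units; beyond the scatter), and the furthest is compound 2, reached by a 6.2-fold lower number from compound 1 to compound 2 (0.79 log units; beyond the scatter). Compound 4, `O=C(O)CCCC/C=C(\c1cccnc1)c1cccc([N+](=O)[O-])c1`, differs from compound 1 by nitro in place of bromo on an aromatic carbon, meta to a large group. Within the data shown here, no measured step exchanges one substituent for another on the same aromatic carbon; the two steps from compound 1 only move the bromo or replace the whole ring, and both were modest. The step to compound 4 is therefore expected to be modest at most, with its direction uncertain, estimated as a 1.2-fold lower number from compound 1 to compound 4 (0.08 log units; within the scatter). Compound 4 is expected to give about 150 nM, between 50 nM and 450 nM.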

Compound 4, half-maximal inhibitory concentration: 73 nM
Estimate against measurement, compound 4: 2.1-fold (0.31 log units) above, within the range that was stated.
By their numbers in this assay, from the lowest: compound 2; then compounds 4 and 3 (each within the scatter of the next); then compound 1.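

In this assay, the exchange of bromo for nitro gives a 2.5-fold lower number from compound 1 to compound 4 (0.39 log units; beyond the scatter) at this place, meta to a large group. Among these compounds, this is the first sign that the position responds to a change of substituent on the same aromatic carbon, and not only to moving the bromo or replacing the whole ring. The larger nitro, with its hydrogen-bond acceptors, is accepted here with a lower number, not a higher one.

Whether an amine or a nitrile on this carbon would follow nitro remains open, and no evidence here bears on what lies behind the step.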